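Furan-2-yl to 1H-pyrrol-2-yl swap on two cores

The source may hold more compounds than are shown below. What is called first, only, known or untested is meant among the compounds shown, and "the series" means these compounds.

Measured so far in a functional assay on the whole organism (strain Wistar Albino) for inhibition, with Rattus norvegicus as the target, read by paw edema, with a stated time of 3 h, at a dose of 20 mg/kg; a higher number here means more inhibition at the dose given (going by the name of the read-out), a lower number less inhibition:
compound 1, `COc1ccc(Cc2nnc3n2NC(c2ccco2)S3)cc1OC`: 21.1%
compound 2, `Cc1occc1-c1nnc2n1NC(c1ccco1)S2`: 24.1%
compound 3, `COc1ccc(Cc2nnc3n2NC(c2ccc[nH]2)S3)cc1OC`: 17.7%

All three numbers in this assay lie within the usual scatter of one another, so none of the three is set apart from the others by this read-out. Compound 2 has the highest of the three numbers, but compound 1 and compound 3 sit close enough that no order can be read from it.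

Compound 1 and compound 3 share a core and differ in one place: 1H-pyrrol-2-yl in place of furan-2-yl on a saturated ring carbon. This change gave a number 3.4 percentage points lower from compound 1 to compound 3 (within the scatter), a step that the scatter swallows.

Compound 1 and compound 2 carry different cores; the difference between the two cores is not broken down here, and only their two values are compared above.

Not yet measured is compound 4, `Cc1occc1-c1nnc2n1NC(c1ccc[nH]1)S2`. It stands to compound 2 as compound 3 stands to compound 1, the same change on the same place: 1H-pyrrol-2-yl in place of furan-2-yl on a saturated ring carbon.

Since this change is seen once, in the pair compound 1 to compound 3, and the step there is a number 3.4 percentage points lower from compound 1 to compound 3 (within the scatter), the expectation for compound 2 to compound 4 is a step of similar size, estimated as a number 3.4 percentage points lower from compound 2 to compound 4 (within the scatter). On that basis compound 4 is expected to give about 20.7% in this assay, with a likely range of 12% to 29%, which would leave it within the scatter of compound 2.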

Compound 4, a percentage reported as inhibition, in the whole organism at one dose (the size of the read-out at that dose, not a potency): 20.3%
Compound 4: middle estimate off by 0.4 percentage points, on the high side, and the stated range covers the measured number.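

In this assay, the exchange of furan-2-yl for 1H-pyrrol-2-yl on a saturated ring carbon can now be read on two cores, and the new step is a number 3.8 percentage points lower from compound 2 to compound 4 (within the scatter). Set beside the earlier step, the two steps agree: the same change on two cores in this assay, a number 3.4 percentage points lower (within the scatter) from compound 1 to compound 3 and a number 3.8 percentage points lower (within the scatter) from compound 2 to compound 4, 0.4 percentage points apart, within the scatter of two such steps. Within this small set, the change therefore carries from the core of compound 1 to the core of compound 2 with no difference in step size that can be told apart, but each step lies within the scatter, so the pairs do not show that the exchange alters inhibition on either core, and two pairs at a single dose give no rule for any further core.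

Left open is how other groups behave in the same place on the saturated ring carbon, for instance thiophen-2-yl, phenyl, or a phenyl carrying an amine or a carboxylic acid. Also open, on these data alone, is whether any exchange at that place gives a step beyond the scatter in this assay, and whether the agreement between the two steps would hold on a third core or at another dose.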